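A few compounds are considered here, and "the series" means these few. Any claim that something is new, unique, unknown or untested is made for them only; others in the source may bear on it.

Compound 1 `CCC(=O)c1cc(-c2ccc(C)cc2)n(-c2ccc(S(N)(=O)=O)cc2)c1C` gives 1000 nM
Compound 2 `CCC(=O)c1cc(-c2cccc(Cl)c2)n(-c2ccc(S(N)(=O)=O)cc2)c1C` gives 12600 nM
Compound 3 `CCC(=O)c1cc(-c2ccc(Cl)cc2Cl)n(-c2ccc(S(N)(=O)=O)cc2)c1C` gives 7700 nM

All three were read in a physicochemical assay for solubility, read by HPLC, in phosphate buffer, measured as kinetic solubility, at pH 7.4 (on this read-out higher numbers stand for higher solubility and lower numbers for lower solubility), and compound 1 holds the lowest number of them. Compound 4 `Cc1ccc(-c2cc(C(=O)O)c(C)n2-c2ccc(S(N)(=O)=O)cc2)cc1` keeps the core of compound 1 and differs by hydroxy in place of ethyl on a carbonyl carbon in one change, propanoyl to carboxy. Among the measured compounds shown here, no measured step touches that place, so the measured steps give only a scale. There is a 13-fold higher number from compound 1 to compound 2 (1.10 log units; beyond the scatter) which is large, and a 7.7-fold higher number from compound 1 to compound 3 (0.89 log units; beyond the scatter) which is modest, while a 1.6-fold lower number from compound 2 to compound 3 (0.21 log units; within the scatter) stays within the scatter. For the measured compounds named here, a large upward step in this assay is expected, although no measured compound carries carboxy. The expected value for compound 4 is 40000 nM with an estimated range from 6000 nM to 200000 nM in this read-out. The estimate means a 40-fold higher number from compound 1 to compound 4 (1.60 log units; beyond the scatter) as the expected step.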

Compound 4, solubility: 10000 nM
Compound 4: middle estimate off by 4.0-fold (0.60 log units), on the high side; measured number inside the range.
By their numbers in this assay, from the lowest: compound 1; then compounds 3, 4 and 2 (each within the scatter of the next).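

In this assay, the change from propanoyl to carboxy gives a 10-fold higher number from compound 1 to compound 4 (1.00 log units; beyond the scatter), so the carbonyl carbon joins the 4-methylphenyl group as a place where a single change moves the number beyond the scatter. Until now, only changes to that aryl group had been seen to do this. Nothing available here explains the step. The compounds shown leave open whether an amide or a methyl ester at this place would give a similar step. They also leave open whether carboxy would do so alongside 3-chlorophenyl or 2,4-dichlorophenyl.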